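Notes on compound 3 to compound 4

This account rests on a few compounds, and the source may have more. Where it says the series, first, only, none or still open, it means among the compounds named here.

Measured compounds in a functional assay on DU-145 cells (Homo sapiens) for inhibition, read by trypan blue exclusion, with a stated time of 72 h (on this read-out lower numbers stand for stronger inhibition and higher numbers for weaker inhibition), as follows
compound 1 `COc1ccc(Nc2ncc3cc(S(=O)(=O)c4ccc(C)cc4)c(=O)n(C)c3n2)cc1` gives 100000 nM
compound 2 `Cc1ccc(S(=O)(=O)c2cc3cnc(Nc4ccc5cc[nH]c5c4)nc3n(C)c2=O)cc1` gives 15000 nM
compound 3 `Cn1c(=O)c(S(=O)(=O)c2ccc(O)cc2)cc2cnc(Nc3ccc4[nH]ccc4c3)nc21` gives 250 nM

Compound 3 has the lowest number of the three, well under compound 2 and further still under compound 1. Compound 4 `Cc1ccc(S(=O)(=O)c2cc3cnc(Nc4ccc5[nH]ccc5c4)nc3n(C)c2=O)cc1` differs from compound 3 at one place only: methyl in place of hydroxy on an aromatic carbon (methyl in place of hydroxy on an aromatic carbon, para to a large group), so that (4-hydroxyphenyl)sulfonyl becomes (4-methylphenyl)sulfonyl.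

Among the measured compounds shown here, the one measured step, a 6.7-fold lower number from compound 1 to compound 2 (0.82 log units; beyond the scatter) and modest in size, is 1H-indol-6-yl in place of 4-methoxyphenyl on a nitrogen. It lies away from the sulfonyl side and bears only indirectly. For the measured compounds named here, no measured step isolates the change from hydroxy to methyl. Compound 4 shares the 4-methylphenyl with compound 2, which gives 15000 nM with a different group on that nitrogen. Compound 3 differs from compound 2 in both places, so the gap between their values cannot be divided between the two. A step to a higher number in this assay beyond the scatter is expected, though smaller than that whole gap. The expected change is a 6.0-fold higher number from compound 3 to compound 4 (0.78 log units; beyond the scatter) in this estimate. For compound 4 the estimated value is 1500 nM with an expected range from 300 nM to 8000 nM in this assay.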

Compound 4, half-maximal inhibitory concentration: 750 nM
Beside the measured number, compound 4's estimate is 2.0-fold (0.30 log units) above it, and the stated range covers the measured number.
By their numbers in this assay, from the lowest: compound 3; then compound 4; then compound 2; then compound 1.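

In this assay, among the compounds shown here, the step of a 3.0-fold higher number from compound 3 to compound 4 (0.48 log units; beyond the scatter) is the first reading of methyl in place of hydroxy taken alone, with 1H-indol-5-yl held constant on the nitrogen: it is modest but beyond the scatter, so the 4-hydroxyphenyl gives the lower number of this pair, and the 4-methylphenyl still leaves compound 4 with a far lower number than compound 2 or compound 1. With the (4-methylphenyl)sulfonyl held constant, the step of a 20-fold lower number from compound 2 to compound 4 (1.30 log units; beyond the scatter) for 1H-indol-5-yl in place of 1H-indol-6-yl and the step of a 130-fold lower number from compound 1 to compound 4 (2.12 log units; beyond the scatter) for 1H-indol-5-yl in place of 4-methoxyphenyl are both large, and each exceeds the change from hydroxy to methyl among these compounds. Nothing at hand explains the size or direction of any of these steps.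

On these data alone, what an amine or a carboxylic acid would give on this aromatic carbon remains open, since only hydroxy and methyl can be read here. Also open, as far as these compounds go, is whether the change from hydroxy to methyl gives a similar step with 1H-indol-6-yl or 4-methoxyphenyl on the nitrogen, since it has been read only with 1H-indol-5-yl.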